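Alkylamine Chain Length and Cytotoxicity: Compound 4 Expected

The source may hold more compounds than are shown below. What is called first, only, known or untested is meant among the compounds shown, and "the series" means these compounds.

Compound 1 `CCCCCCNc1cncc(C(=O)NCc2ccccc2)n1`: in an ADME assay on HEL cells (Homo sapiens) for cytotoxicity, read by microscopy, with a stated time of 6 days (on this read-out lower numbers stand for higher toxicity in this test and higher numbers for lower toxicity in this test), compound 1 gives only a limit, > 100000 nM.
Compound 2 `CCCCNc1cncc(C(=O)NCc2ccccc2)n1`: in this assay compound 2 gives only a limit, > 100000 nM.
Compound 3 `CCCCCCCNc1cncc(C(=O)NCc2ccccc2)n1`: in this assay compound 3 gives only a limit, > 100000 nM.

Compound 3 stands where every measured compound stands, at a limit rather than a number, because of the limit of > 100000 nM in this assay, at which 3 of the 3 values shown sit. The three steps among the measured compounds, a step that the two limits leave unreadable from compound 1 to compound 2, a step that the two limits leave unreadable from compound 1 to compound 3 and a step that the two limits leave unreadable from compound 2 to compound 3, are all unreadable. Compound 4 `CCCCCNc1cncc(C(=O)NCc2ccccc2)n1` differs from compound 3 by hydrogen in place of ethyl on a saturated chain carbon, five bonds along the chain from a nitrogen on an aromatic ring. Shortening and lengthening this same chain among compounds 1, 2 and 3 gave no readable step, so no step beyond the scatter is expected in this assay. The expected step from compound 3 to compound 4 is a number no higher from compound 3 to compound 4 (the limit leaves the size open). Compound 4 is therefore estimated at 100000 nM, with a range from 50000 nM to 300000 nM, most likely again as a limit.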

Compound 4, minimum cytotoxic concentration: > 100000 nM
Compound 4: a limit, no number; the forecaster's own chance of this, stated with the estimate: 90%; the middle value sits exactly at the limit.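

Compound 4 gives only a limit in this assay, so no step among compound 1, compound 2, compound 3 and compound 4 can be read: the limit of > 100000 nM in this assay, at which 4 of the 4 values shown sit.

Going by these compounds, whether chain length changes the read-out in this assay at all stays open.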